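A few compounds are considered here, and "the series" means these few. Any claim that something is new, unique, unknown or untested is made for them only; others in the source may bear on it.

Measured compounds:
compound 1 `O=C(CC1CCCCCC1)N1CCC(c2nc(-c3ccc4ccccc4n3)no2)CC1` — 840 nM in a functional assay on Shh Light II cells (Mus musculus) for inhibition, read by a luciferase reporter; on this read-out higher numbers stand for weaker inhibition and lower numbers for stronger inhibition
compound 2 `CC(C)c1ccccc1NC(=O)N1CCC(c2nc(-c3ccc4ccccc4n3)no2)CC1` — 480 nM in this assay

Compound 1 gives the larger of these two numbers, separated from compound 2 by a 1.8-fold lower number from compound 1 to compound 2 (0.24 log units; within the scatter). Compound 3 `COc1ccccc1NC(=O)N1CCC(c2nc(-c3ccc4ccccc4n3)no2)CC1` differs from compound 1 by (2-methoxyphenyl)amino in place of cycloheptylmethyl on a carbonyl carbon. Going by the values given here, the only step that bears on this change is a 1.8-fold lower number from compound 1 to compound 2 (0.24 log units; within the scatter), where a substituted phenylamino likewise replaced cycloheptylmethyl on the carbonyl carbon and the number barely moved. A step of similar size is therefore expected. Compound 3 is expected to give 550 nM, within a range from 200 nM to 1500 nM. The implied step, a 1.5-fold lower number from compound 1 to compound 3 (0.18 log units; within the scatter), is expected to remain within the scatter.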

Compound 3, half-maximal inhibitory concentration: 410 nM
Compound 3: middle estimate off by 1.3-fold (0.13 log units), on the high side; low and high end bracket the measured number.
By their numbers in this assay, from the lowest: compounds 3, 2 and 1 (each within the scatter of the next, the first and the last beyond it).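

In this assay, going by these compounds alone, (2-methoxyphenyl)amino in place of cycloheptylmethyl on the carbonyl carbon gives a 2.0-fold lower number from compound 1 to compound 3 (0.31 log units; beyond the scatter), the first step at this position to pass the scatter, though only modestly. Methoxy in place of isopropyl on the aromatic carbon gives a 1.2-fold lower number from compound 2 to compound 3 (0.07 log units; within the scatter), so these two substituents cannot be told apart on this read-out. No evidence is available that bears on the reason for either step.

Going by these compounds, how an unsubstituted phenylamino group would compare remains open. So does the effect of a chlorine or a carboxylic acid in place of methoxy on the aromatic carbon.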